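The source may report more compounds than this note shows. Statements on the series, on what has been measured and on what is new or still open speak of the compounds shown alone.

Working notes on the aryl substituent of the piperazine series.

Compound 1 `CCOc1ccccc1N1CCN(CCCCn2ncc(=O)n(C)c2=O)CC1` gives 1.8 nM in an assay for displacement of a labelled ligand from Adrenergic receptor alpha-1 (Homo sapiens); a higher number here means a weaker inhibitor, a lower number a stronger inhibitor. Compound 2 `CNc1ccccc1N1CCN(CCCCn2ncc(=O)n(C)c2=O)CC1` gives 450 nM in this assay, and compound 3 `Cn1c(=O)cnn(CCCCN2CCN(c3ccccc3)CC2)c1=O` gives 64 nM. Compound 3 thus stands second highest of the three numbers: the step of a 7.0-fold lower number from compound 2 to compound 3 (0.85 log units; beyond the scatter) is modest, whereas the step of a 36-fold higher number from compound 1 to compound 3 (1.55 log units; beyond the scatter) is large, and the step of a 250-fold higher number from compound 1 to compound 2 (2.40 log units; beyond the scatter) separates the two substituted analogues widely.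

Compound 4 `Cn1c(=O)cnn(CCCCN2CCN(c3ccccc3C#N)CC2)c1=O` is not yet measured. It differs from compound 3 by cyano in place of hydrogen on an aromatic carbon. Among the compounds with values here, the steps that bear on this change are the two in which hydrogen on the same aromatic carbon is exchanged for a substituent: removing ethoxy cost a large step from compound 1 to compound 3, while removing methylamino brought a modest gain from compound 2 to compound 3. A substituent bearing one hydrogen-bond acceptor and no donor, as cyano does, is closer to the ethoxy case. A lower number than compound 3 is therefore expected for compound 4, by a step of a 4.3-fold lower number from compound 3 to compound 4 (0.63 log units; beyond the scatter), with the estimate for compound 4 set at 15 nM and its range from 4 nM to 60 nM.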

Compound 4, inhibition constant: 7.3 nM
For compound 4 the middle estimate is 2.1-fold (0.31 log units) above the measured one; low and high end bracket the measured number.
By their numbers in this assay, from the lowest: compound 1; then compound 4; then compound 3; then compound 2.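

In this assay, the aromatic carbon ortho to a large group now carries a second group that improves on hydrogen, with an 8.8-fold lower number from compound 3 to compound 4 (0.94 log units; beyond the scatter), so the gain is not confined to ethoxy, while methylamino in compound 2 still goes against it. Cyano falls short of ethoxy, with a 4.1-fold higher number from compound 1 to compound 4 (0.61 log units; beyond the scatter), yet stands far from methylamino, with a 62-fold lower number from compound 2 to compound 4 (1.79 log units; beyond the scatter), which places the nitrile in the gap between compound 1 and compound 3. No measured evidence bears on what sets these groups apart at this carbon.

Still open, as far as these compounds go, is how methoxy, fluorine, a primary amine or a carboxylic acid would rank at this carbon against cyano and ethoxy. Also open is whether the order among these groups holds with a longer chain on the shared core.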